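Ethoxy to Methoxy: A Small Step to Be Measured

The source may report more compounds than this note shows. Statements on the series, on what has been measured and on what is new or still open speak of the compounds shown alone.

Of the compounds shown here, two have been measured in a functional assay on CHO cells for antagonist activity at adenosine receptor A3 (Homo sapiens), read by cAMP accumulation; on this read-out higher numbers stand for weaker inhibition and lower numbers for stronger inhibition. Compound 1, `O=c1oc2c(O)cccc2cc1-c1ccc(Br)cc1`, gives 3100 nM in this assay. Compound 2, `CCOc1cccc2cc(-c3ccc(OC)cc3)c(=O)oc12`, gives 29500 nM in this assay, the highest of the two numbers and thus the weaker inhibitor of the pair; its gap to compound 1 lies beyond the usual scatter. The two compounds differ in more than one place, so that gap cannot be credited to any single change.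

Compound 3, `COc1ccc(-c2cc3cccc(OC)c3oc2=O)cc1`, has not yet been measured. It differs from compound 2 in one place: hydrogen in place of methyl on a saturated chain carbon bound to an oxygen on an aromatic ring, in other words ethoxy becomes methoxy. For the measured compounds named here, no measured pair shows this change, so its effect is unknown here. Such a small alteration is expected to shift the number only modestly, if at all, and the expected step is a 2.0-fold lower number from compound 2 to compound 3 (0.29 log units; within the scatter), toward a somewhat lower number. Compound 3 is therefore expected to give about 15000 nM in this assay, within a range of 4000 nM to 50000 nM.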

Compound 3, half-maximal inhibitory concentration: 25300 nM
Beside the measured number, compound 3's estimate is 1.7-fold (0.23 log units) below it; the range from low to high includes it.
By their numbers in this assay, from the lowest: compound 1; then compounds 3 and 2 (each within the scatter of the next).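

In this assay, for the compounds shown here, cutting ethoxy down to methoxy gives a 1.2-fold lower number from compound 2 to compound 3 (0.07 log units; within the scatter), the first step here between two compounds that differ in one place. On this shared core, then, the methyl at the end of the ethoxy chain, on a saturated chain carbon bound to an oxygen on an aromatic ring, can go without any change that this read-out can tell apart from scatter. Nothing measured here speaks to the reason for this result.

Going by these compounds, whether a longer chain on that oxygen, such as propyl or butyl, or a chain ending in an amine would read the same remains open. This single step also cannot say whether the same change would be as quiet on a different core, such as that of compound 1.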